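A few compounds are considered here, and "the series" means these few. Any claim that something is new, unique, unknown or untested is made for them only; others in the source may bear on it.

Notes on the series

Compound 1 `Nc1c(-c2ccc(Br)cc2)nc2ncccn12` is the smaller member, carrying an unsubstituted amino group. In a toxicity assay on A549 cells (Homo sapiens) for cytotoxicity, read by luminescence and CellTiter-Glo, with a stated time of 48 h (on this read-out lower numbers stand for higher toxicity in this test and higher numbers for lower toxicity in this test), compound 1 gives > 100000 nM, which is a limit of the assay rather than a measured number. Compound 2 `CCNC(=O)CCCOc1ccc(-c2nc3ncccn3c2NC2CCCCC2)cc1` extends the scaffold with a cyclohexylamino group and an ether-linked chain ending in an ethylamide. In this assay compound 2 gives > 100000 nM, again a limit and not a number. Compound 2 therefore stands where every value in the set stands: the limit of > 100000 nM in this assay, at which 2 of the 2 values shown sit. Within the data shown here, no step between two measured values exists in this set, so no measured change can be read off.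

Compound 3 `CCOC(=O)CCCOc1ccc(-c2nc3ncccn3c2NC2CCCCC2)cc1` is the unmeasured analogue of compound 2; the difference is ethoxy in place of ethylamino on a carbonyl carbon, in words ethoxy in place of ethylamino on a carbonyl carbon. With both measured compounds sitting at the limit, no direction can be taken from the data, and the step from compound 2 to compound 3 is expected to be a step that the limit leaves unreadable from compound 2 to compound 3, that is, nothing beyond the scatter. Compound 3 is accordingly estimated at 120000 nM in this assay, with a plausible range from 30000 nM to 400000 nM, most likely reported again as a limit.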

Compound 3, half-maximal cytotoxic concentration: > 100000 nM
Compound 3 ended at the assay's limit; the forecaster's own chance of this, stated with the estimate: 70%; the middle value lies beyond the limit too.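

No step can be read from compound 2 to compound 3 in this assay because all the compounds shown sit at one limit: the limit of > 100000 nM in this assay, at which 3 of the 3 values shown sit.

The compounds shown leave open whether ethoxy in place of ethylamino on a carbonyl carbon, or any other change to the shared core, alters the read-out in this assay at all.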